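Thiophen-2-yl for furan-2-yl on the shared core

The source may report more compounds than this note shows. Statements on the series, on what has been measured and on what is new or still open speak of the compounds shown alone.

In a functional assay on SK-MEL-2 cells (Homo sapiens) for antiproliferative activity (on this read-out lower numbers stand for stronger inhibition of growth and higher numbers for weaker inhibition of growth), compound 1 `c1ccc(-c2cc(-c3ccccn3)nc(-c3ccccn3)c2)cc1` gives 7.5 ug/mL and compound 2 `c1ccc(-c2cc(-c3ccco3)cc(-c3ccccn3)n2)nc1` gives 9.9 ug/mL, so compound 2 stands within the scatter of compound 1. Compound 3 `c1ccc(-c2cc(-c3cccs3)cc(-c3ccccn3)n2)nc1` has thiophen-2-yl in place of furan-2-yl on an aromatic carbon, opposite the ring nitrogen: thiophen-2-yl in place of furan-2-yl on an aromatic carbon. Going by the values given here, the one measured step at this place, furan-2-yl in place of phenyl, is a 1.3-fold higher number from compound 1 to compound 2 (0.12 log units; within the scatter) and stays within the scatter. No step beyond the scatter is therefore expected in this assay. The expected step is a 1.1-fold lower number from compound 2 to compound 3 (0.04 log units; within the scatter). The estimate for compound 3 is 9 ug/mL, with an expected range of 4.5 ug/mL to 18 ug/mL.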

Compound 3, concentration for 50% growth inhibition: 1.8 ug/mL
Estimate against measurement, compound 3: 5.0-fold (0.70 log units) above; measured number outside the range, below it.
By their numbers in this assay, from the lowest: compound 3; then compounds 1 and 2 (each within the scatter of the next).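

At this position the identity of the five-membered ring matters: exchanging furan-2-yl for thiophen-2-yl, with the oxygen replaced by sulfur, gives a 5.5-fold lower number from compound 2 to compound 3 (0.74 log units; beyond the scatter) in this assay, although furan-2-yl and phenyl had stayed within the scatter of each other. Thiophen-2-yl also separates from phenyl, with a 4.2-fold lower number from compound 1 to compound 3 (0.62 log units; beyond the scatter), so only the thiophene stands apart among the three groups. Nothing available explains this gain.

Open, as far as these compounds go, is whether the gain depends on the attachment point, as thiophen-3-yl would show, or survives a methyl group on the thiophene. Also open, from the compounds shown here alone, is how an aliphatic amine would fare on this carbon.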